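The source may report more compounds than this note shows. Statements on the series, on what has been measured and on what is new or still open speak of the compounds shown alone.

Three compounds of the shared core have numbers in a functional assay on HEK293 cells for activation of melanin-concentrating hormone receptor 1 (Homo sapiens), read by inositol phosphate accumulation; a higher number here means that more compound is needed for the effect, a lower number that less compound is needed. Compound 1 `CCCc1cc(N)c2cc(NC(=O)/C=C/c3ccc(C(C)(C)C)cc3)ccc2n1` gives 910 nM, compound 2 `CCCc1cc(N)c2cc(NC(=O)/C=C/c3ccc(C(C)C)cc3)ccc2n1` gives 520 nM, and compound 3 `CCCCc1ccc(/C=C/C(=O)Nc2ccc3nc(CCC)cc(N)c3c2)cc1` gives 740 nM. Compound 2 has the lowest of the three numbers, yet the steps of a 1.8-fold lower number from compound 1 to compound 2 (0.24 log units; within the scatter) and a 1.4-fold higher number from compound 2 to compound 3 (0.15 log units; within the scatter) both lie within the scatter, so no order among the three can be claimed. Going by the values given here, every measured step so far exchanges one alkyl group for another on the aromatic carbon: a 1.8-fold lower number from compound 1 to compound 2 (0.24 log units; within the scatter), a 1.2-fold lower number from compound 1 to compound 3 (0.09 log units; within the scatter) and a 1.4-fold higher number from compound 2 to compound 3 (0.15 log units; within the scatter), none beyond the scatter.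

Compound 4 `CCCc1cc(N)c2cc(NC(=O)/C=C/c3ccc(Cl)cc3Cl)ccc2n1` is not yet measured. It differs from compound 2 by 2,4-dichlorophenyl in place of 4-isopropylphenyl on a double-bonded chain carbon bound to a double-bonded chain carbon. Among the compounds with values here, no measured step exchanges the whole aryl group or brings in chlorine, so the three steps bear on this change only in showing that variation on that ring has so far moved this assay by less than the scatter. The expected step is therefore a 1.3-fold higher number from compound 2 to compound 4 (0.13 log units; within the scatter), with wide uncertainty. The estimated value for compound 4 is 700 nM, in the range 200 nM to 2500 nM.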

Compound 4, half-maximal effective concentration: 904 nM
Beside the measured number, compound 4's estimate is 1.3-fold (0.11 log units) below it, and the stated range covers the measured number.
By their numbers in this assay, from the lowest: compounds 2, 3, 4 and 1 (each within the scatter of the next).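

Working notes on the aryl group: in this assay, the exchange of 4-isopropylphenyl for 2,4-dichlorophenyl on the double-bonded chain carbon gives a 1.7-fold higher number from compound 2 to compound 4 (0.24 log units; within the scatter) and is the first step that replaces the whole aryl group and brings in chlorine. Variation at this place is therefore no longer confined to alkyl groups, and a ring with two chlorines and no alkyl group still gives a step within the scatter. The data offer no measured basis for interpreting this step.

Going by these compounds, whether a single chlorine, a methoxy group, an amine or a carboxylic acid on this ring would give a step beyond the scatter remains open. The separate contributions of the two chlorines in 2,4-dichlorophenyl also remain unresolved.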